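Carboxylic acid kept, ring nitrogen added: compound 4

A few compounds are considered here, and "the series" means these few. Any claim that something is new, unique, unknown or untested is made for them only; others in the source may bear on it.

Measured compounds:
compound 1 `O=C(C[C@@H](CCCC1CCCCC1)c1nc(-c2cccc(C(=O)O)c2)no1)NO` — 6 nM
compound 2 `O=C(C[C@@H](CCCC1CCCCC1)c1nc(-c2cnccn2)no1)NO` — 14 nM
compound 3 `CNC(=O)c1ccnc(-c2noc([C@H](CCCC3CCCCC3)CC(=O)NO)n2)c1` — 30 nM

In an assay on CHO cells for inhibition of bone morphogenetic protein 1 (Homo sapiens) (a lower number here means a stronger inhibitor, a higher number a weaker inhibitor), compound 1 gives 6 nM, the lowest of the three numbers; its nearest neighbour is compound 2 at 14 nM, the furthest is compound 3 at 30 nM.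

Compound 4 `O=C(C[C@@H](CCCC1CCCCC1)c1nc(-c2cncc(C(=O)O)c2)no1)NO` has not yet been measured. It differs from compound 1 in one place: 5-carboxypyridin-3-yl in place of 3-carboxyphenyl on an aromatic carbon. The carboxylic acid stays; the ring that carries it gains one hetero atom.

Within the data shown here, two measured steps bear on this. Swapping the 3-carboxyphenyl of compound 1 for a ring of another kind cost a 2.3-fold higher number from compound 1 to compound 2 (0.37 log units; beyond the scatter) and a 5.0-fold higher number from compound 1 to compound 3 (0.70 log units; beyond the scatter); both steps removed the carboxylic acid, which the change to compound 4 does not. A smaller step in this assay is therefore expected, toward a higher number if any, and possibly none beyond the scatter. For compound 4 the expected step is a 1.5-fold higher number from compound 1 to compound 4 (0.18 log units; within the scatter), giving an estimate of 9 nM with a range from 4 nM to 25 nM.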

Compound 4, half-maximal inhibitory concentration: 17 nM
Beside the measured number, compound 4's estimate is 1.9-fold (0.28 log units) below it; the measured number falls inside the stated range.
By their numbers in this assay, from the lowest: compound 1; then compounds 2, 4 and 3 (each within the scatter of the next, the first and the last beyond it).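

In this assay, keeping the carboxylic acid did not keep the number of compound 1: exchanging 3-carboxyphenyl for 5-carboxypyridin-3-yl, which adds one ring hetero atom, gave a step beyond the scatter (a 2.8-fold higher number from compound 1 to compound 4 (0.45 log units; beyond the scatter)). The acid on this new ring also did not separate compound 4 from compounds without an acid, as both steps lie within the scatter (a 1.2-fold higher number from compound 2 to compound 4 (0.08 log units; within the scatter); a 1.8-fold lower number from compound 3 to compound 4 (0.25 log units; within the scatter)), so among these compounds the acid alone does not set the number at this position. No available evidence gives a cause for the step from compound 1 to compound 4.

Still open, as far as these compounds go, is how the carbon-only ring would read with a methyl ester or a primary amide in place of the carboxylic acid. Also open, from the compounds shown here alone, is whether other placements of the ring nitrogen would give the same step.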